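The compounds below may be only part of what the source reports. "The series", "measured", "known", "first", "only" and "open" are said of these compounds alone.

Measured compounds:
- compound 1 `O=C1O/C(=C\Cn2cc(C(F)(F)F)c(=O)[nH]c2=O)C(OCc2ccccc2)=C1OCc1ccccc1`: in a functional assay on MIA PaCa-2 cells (Homo sapiens) for inhibition (on this read-out higher numbers stand for weaker inhibition and lower numbers for stronger inhibition), compound 1 gives 30000 nM.
- compound 2 `O=C1O/C(=C\Cn2cnc3c(-n4cccc4)ncnc32)C(OCc2ccccc2)=C1OCc1ccccc1`: in this assay compound 2 reaches only a limit of the assay, > 100000 nM, not a number.

Within the data shown here, compound 1 therefore holds the only actual number in this assay; the other entry for the series is a limit, as the limit of > 100000 nM in this assay, at which 1 of the 2 values shown sits, records. The unmeasured compound 3 `O=C1O/C(=C\Cn2cc(Cl)c(=O)[nH]c2=O)C(OCc2ccccc2)=C1OCc1ccccc1` differs from compound 1 in a single place: chloro in place of trifluoromethyl on an aromatic carbon. Among the measured compounds shown here, no step between two measured compounds is available, so the size of this change cannot be read from any precedent. The group that leaves and the group that enters sit at the same place on the same ring, and the counted difference is modest, so the step is expected to remain within the usual scatter of this assay, with at most a slight drift toward weaker inhibition. For compound 3 the value in this assay is estimated at 40000 nM, with a range from 12000 nM to 120000 nM. The step from compound 1 to compound 3 is accordingly expected to amount to a 1.3-fold higher number from compound 1 to compound 3 (0.12 log units; within the scatter).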

Compound 3, half-maximal inhibitory concentration: 40000 nM
For compound 3 middle estimate and measured number coincide at the digits printed; the measured number falls inside the stated range.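

In this assay, the aromatic carbon two atoms from the ring nitrogen now has its first readable step: chloro in place of trifluoromethyl gives a 1.3-fold higher number from compound 1 to compound 3 (0.12 log units; within the scatter). The step replaces a group of 4 heavy atoms with one of 1 heavy atom, and the read-out does not separate the two groups, so at this place the exchange leaves the number within the scatter. Compound 2 remains a limit of the assay and not a number, and no step to it can be read: the limit of > 100000 nM in this assay, at which 1 of the 3 values shown sits.

The compounds shown leave open whether this flat response extends to other kinds of group at this place, such as a hydrogen, an amine, a nitrile or a carboxylic acid, since a single step between two halogen-bearing groups sets no pattern. Also open, going by these compounds, is whether changes elsewhere on the shared core, for instance at the chain carrying the ring or at the two ether groups, would move the number in this assay beyond the scatter.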